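Octylsulfanyl to Benzylsulfanyl: Cytotoxicity Expected to Stay Low

A few compounds are considered here, and "the series" means these few. Any claim that something is new, unique, unknown or untested is made for them only; others in the source may bear on it.

Compound 2 `CCCCCCCCSc1nc(N)nc2c1ncn2/C=C1/CC1(CO)CO` was tested in an ADME assay on BCBL1 cells (Homo sapiens) for cytotoxicity, with a stated time of 7 days; on this read-out higher numbers stand for lower toxicity in this test and lower numbers for higher toxicity in this test. In this assay compound 2 reaches only the limit > 20000 nM. Compound 1 `Nc1nc(N2CCCC2)c2ncn(/C=C3/CC3(CO)CO)c2n1` in this assay likewise gives only the limit > 20000 nM. The change from compound 1 to compound 2, octylsulfanyl in place of pyrrolidin-1-yl on an aromatic carbon, is therefore a step that the two limits leave unreadable from compound 1 to compound 2. Compound 3 `Nc1nc(SCc2ccccc2)c2ncn(/C=C3/CC3(CO)CO)c2n1` differs from compound 2 by phenyl in place of heptyl on a saturated chain carbon bound to a sulfur. Within the data shown here, no measured step offers a readable size, because of the limit of > 20000 nM in this assay, at which 2 of the 2 values shown sit. Compound 3 is therefore expected to remain at the limit, with the step that the limit leaves unreadable from compound 2 to compound 3 expected to be none beyond the scatter. The estimate for compound 3 is 25000 nM, between 10000 nM and 60000 nM.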

Compound 3, half-maximal cytotoxic concentration: > 20000 nM
Compound 3 gave a limit, no number; the forecaster's own chance of this, stated with the estimate: 80%; the middle value is on the limit's open side.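

Compound 1, compound 2 and compound 3 all give only a limit, not a number, so no step among them can be read: the limit of > 20000 nM in this assay, at which 3 of the 3 values shown sit.

The compounds shown leave open whether pyrrolidin-1-yl, octylsulfanyl and benzylsulfanyl differ at all in this assay.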